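From 4-chlorophenyl to pyridin-3-yl on a shared core

A few compounds are considered here, and "the series" means these few. Any claim that something is new, unique, unknown or untested is made for them only; others in the source may bear on it.

Of the compounds shown here, three with a shared core have been tested in a functional assay on MCF7 cells (Homo sapiens) for cytotoxicity, read by ELISA, with a stated time of 4 days; a lower number here means a stronger inhibitor, a higher number a weaker inhibitor. Compound 1 `Cc1ccsc1-c1cc(-c2ccc(Cl)o2)cc(-c2ccco2)n1` gives 5570 nM, compound 2 `Cc1ccsc1-c1cc(-c2ccc(Cl)o2)cc(-c2cccc(Cl)c2)n1` gives 18800 nM, and compound 3 `Cc1ccsc1-c1cc(-c2ccc(Cl)o2)cc(-c2ccc(Cl)cc2)n1` gives 15300 nM. Compound 3 cannot be told apart from its 3-chlorophenyl partner, with a 1.2-fold lower number from compound 2 to compound 3 (0.09 log units; within the scatter). Its number is clearly higher than that of the furan-2-yl compound, with a 2.7-fold higher number from compound 1 to compound 3 (0.44 log units; beyond the scatter), and the 3-chlorophenyl group gives a similar result, with a 3.4-fold higher number from compound 1 to compound 2 (0.53 log units; beyond the scatter).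

Compound 4 `Cc1ccsc1-c1cc(-c2ccc(Cl)o2)cc(-c2cccnc2)n1` has pyridin-3-yl in place of 4-chlorophenyl on an aromatic carbon. Within the data shown here, no measured step makes this exact swap. The closest guide is the furan-2-yl change, since compound 1 also lacks the chlorophenyl group and a 2.7-fold higher number from compound 1 to compound 3 (0.44 log units; beyond the scatter) runs the other way. A modest fall in the number is therefore expected in this assay, although it could stay within the scatter. The estimated step is a 1.8-fold lower number from compound 3 to compound 4 (0.26 log units; within the scatter). Compound 4 is expected near 8500 nM, with an estimated range of 3500 nM to 20000 nM.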

Compound 4, half-maximal inhibitory concentration: 5810 nM
The estimate for compound 4 lay 1.5-fold (0.17 log units) above the measured number; the measured number falls inside the stated range.
By their numbers in this assay, from the lowest: compounds 1 and 4 (each within the scatter of the next); then compounds 3 and 2 (each within the scatter of the next).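

In this assay, a pyridin-3-yl ring, which carries a ring nitrogen and a hydrogen-bond acceptor, gives a clearly lower number than either chlorophenyl ring (a 2.6-fold lower number from compound 3 to compound 4 (0.42 log units; beyond the scatter); a 3.2-fold lower number from compound 2 to compound 4 (0.51 log units; beyond the scatter)). Pyridin-3-yl and furan-2-yl cannot be told apart (a 1.0-fold higher number from compound 1 to compound 4 (0.02 log units; within the scatter)), so among these four compounds the two rings with a hetero atom form one group and the two chlorophenyl rings another, with no compound going against this split. Nothing measured here explains the split.

The compounds shown leave open whether the lower numbers follow from losing the chlorine or from having a hetero atom in the ring, a question that a plain phenyl group at this position would help to separate. They also leave open how a non-ring group, such as an amine or a carboxylic acid, would behave here.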